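Methylating the hydroxy group of compound 2

The source may hold more compounds than are shown below. What is called first, only, known or untested is meant among the compounds shown, and "the series" means these compounds.

Measured so far in a functional assay on WI-38 cells (Homo sapiens) for antiproliferative activity, read by MTT assay; on this read-out lower numbers stand for stronger inhibition and higher numbers for weaker inhibition:
- Compound 1 `O=C(NCCNc1cc(-c2cn(-c3ccccc3)nc2-c2cccc(O)c2)ccn1)Nc1ccc(Cl)c(Cl)c1` gives 17400 nM
- Compound 2 `O=C(NCCCNc1cc(-c2cn(-c3ccccc3)nc2-c2cccc(O)c2)ccn1)Nc1ccc(F)cc1` gives 16800 nM

Compound 2 at 16800 nM sits level with compound 1 within the usual scatter, so neither can be ranked ahead of the other. Compound 3 `COc1cccc(-c2nn(-c3ccccc3)cc2-c2ccnc(NCCCNC(=O)Nc3ccc(F)cc3)c2)c1` has not yet been measured. It differs from compound 2 in one place: methyl in place of hydrogen on an oxygen on an aromatic ring, which turns 3-hydroxyphenyl into 3-methoxyphenyl.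

Going by the values given here, only one measured step exists, a 1.0-fold lower number from compound 1 to compound 2 (0.02 log units; within the scatter) and it lies within the scatter. Among the compounds with values here, that step concerns a different part of the molecule, and no measured pair tests hydroxy to methoxy, so the guide is weak. A step beyond the scatter in this assay is therefore not expected, and any lean towards a higher number is only a guess. The expected size is a 1.2-fold higher number from compound 2 to compound 3 (0.08 log units; within the scatter) by this estimate. For compound 3 the estimated value is 20000 nM with an expected range from 8000 nM to 50000 nM on this thin evidence.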

Compound 3, half-maximal inhibitory concentration: > 20000 nM
Compound 3: only a limit was reported (the forecaster's own chance of this, stated with the estimate: 15%); the middle value lies on the limit itself.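

Going by these compounds alone, the earlier pair differs at another part of the molecule, so this is the first look at the hydroxy group of 3-hydroxyphenyl, and putting methyl in place of hydrogen on that oxygen gives an at least 1.1-fold higher number from compound 2 to compound 3 (0.07 log units; that floor lies within the scatter). That floor lies within the scatter, but the change brings no lower number in this assay, so 3-methoxyphenyl shows no gain over 3-hydroxyphenyl in this test. Compound 3 is reported only as a limit, so the step has a floor but no upper end: the limit of > 20000 nM in this assay, at which 1 of the 3 values shown sits.

Still open, going by these compounds, is whether the hydrogen on that oxygen matters at all, as the true size of the step could lie within the scatter or well beyond it. Also open, on these data alone, is how the same position would read with an amine or a carboxylic acid in place of the hydroxy group, or with a longer chain on the oxygen, such as ethoxy.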